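The compounds below may be only part of what the source reports. "The series", "measured", "known", "first", "only" and "open" are said of these compounds alone.

Compound 1 `CCCOc1ccc(/C=N/Nc2nc(N)c3ncn([C@@H]4O[C@H](CO)[C@@H](O)[C@H]4O)c3n2)cc1`: in an assay on CHO-K1 cells for displacement of a labelled ligand from adenosine receptor A1 (Homo sapiens), read by scintillation counting, with a stated time of 60 min (a lower number here means a stronger inhibitor, a higher number a weaker inhibitor), compound 1 gives > 10000 nM, which is a limit of the assay rather than a number.
Compound 2 `Nc1nc(N/N=C/C2CCCC2)nc2c1ncn2[C@@H]1O[C@H](CO)[C@@H](O)[C@H]1O`: in this assay compound 2 gives 5.6 nM.
Compound 3 `CCCCc1nc(/C=N/Nc2nc(N)c3ncn([C@@H]4O[C@H](CO)[C@@H](O)[C@H]4O)c3n2)c(Cl)[nH]1`: in this assay compound 3 gives 12 nM.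

Compound 3 holds the higher of the two numbers, with compound 2 the nearest: a 2.1-fold higher number from compound 2 to compound 3 (0.33 log units; beyond the scatter). Compound 4 `Nc1nc(N/N=C/c2ccc(C(F)(F)F)cc2)nc2c1ncn2[C@@H]1O[C@H](CO)[C@@H](O)[C@H]1O` differs from compound 3 in one place: 4-(trifluoromethyl)phenyl in place of 2-butyl-5-chloro-1H-imidazol-4-yl on a carbon with a double bond to nitrogen. For the measured compounds named here, two measured steps bear on this change, an at least 1700-fold lower number from compound 1 to compound 2 (3.25 log units; beyond the scatter) and an at least 830-fold lower number from compound 1 to compound 3 (2.92 log units; beyond the scatter), and in both the one compound carrying a six-membered aromatic ring, compound 1, sits at the limit of > 10000 nM in this assay, at which 1 of the 3 values shown sits. Compound 4 carries such a ring again, so a large move toward the weaker end is expected: a 250-fold higher number from compound 3 to compound 4 (2.40 log units; beyond the scatter). For compound 4 the estimate is 3000 nM, within 300 nM to 30000 nM.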

Compound 4, inhibition constant: 37 nM
Beside the measured number, compound 4's estimate is 81-fold (1.91 log units) above it; measured number below the stated range.
By their numbers in this assay, from the lowest: compound 2; then compound 3; then compound 4. At a limit, above all of these: compound 1.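

A six-membered aromatic ring on this carbon does not by itself cost much, with only a 3.1-fold higher number from compound 3 to compound 4 (0.49 log units; beyond the scatter) and a 6.6-fold higher number from compound 2 to compound 4 (0.82 log units; beyond the scatter) as modest steps. What separates the two compounds carrying that ring is its substituent, with an at least 270-fold lower number from compound 1 to compound 4 (2.43 log units; beyond the scatter) when trifluoromethyl replaces propoxy. Compound 1 alone now sits at a limit: (the limit of > 10000 nM in this assay, at which 1 of the 4 values shown sits).

Still open, going by these compounds, is whether the oxygen or the length of the propoxy chain matters more. A methoxy, a propyl chain or an amine on the same ring would help to separate these possibilities.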